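Swapping the Benzyl Group: What Comes Next?

This account rests on a few compounds, and the source may have more. Where it says the series, first, only, none or still open, it means among the compounds named here.

compound 1 `CNc1cc(-c2ccc3cnn(Cc4ccc(OC)cc4)c3c2)cn(C)c1=O`: 2700 nM
compound 2 `CNc1cc(-c2ccc3cnn(Cc4cc(OC)cc(OC)c4)c3c2)cn(C)c1=O`: 190 nM
compound 3 `CNc1cc(-c2ccc3cnn(Cc4ccc(F)c(F)c4)c3c2)cn(C)c1=O`: not yet measured

These numbers come from a functional assay on MV4-11 cells (Homo sapiens) for antiproliferative activity, read by luminescence and CellTiter-Glo, with a stated time of 72 h; a higher number here means a weaker inhibitor, a lower number a stronger inhibitor. Of the two measured compounds, compound 2 has the lower number, at 190 nM. Compound 3 keeps the shared core but differs in one group: 3,4-difluorophenyl in place of 3,5-dimethoxyphenyl on a saturated chain carbon bound to an aromatic nitrogen. In words, 3,4-difluorophenyl stands in place of 3,5-dimethoxyphenyl on a saturated chain carbon bound to an aromatic nitrogen. Among the compounds with values here, one measured step bears on this change. Putting 3,5-dimethoxyphenyl in place of 4-methoxyphenyl at that same place gave a 14-fold lower number from compound 1 to compound 2 (1.15 log units; beyond the scatter), which shows that the number can respond strongly to this group. No fluorine-bearing group has been measured yet, so the size of the next step is uncertain. The expected step, a rise beyond the scatter, is a 6.3-fold higher number from compound 2 to compound 3 (0.80 log units; beyond the scatter). For compound 3 the estimated value is 1200 nM, with an expected range of 350 nM to 4000 nM.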

Compound 3, half-maximal inhibitory concentration: 320 nM
For compound 3 the middle estimate is 3.8-fold (0.57 log units) above the measured one, outside the stated range (below it).
By their numbers in this assay, from the lowest: compounds 2 and 3 (each within the scatter of the next); then compound 1.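

In this assay, 3,4-difluorophenyl in place of 3,5-dimethoxyphenyl gives a 1.7-fold higher number from compound 2 to compound 3 (0.23 log units; within the scatter), so these two groups cannot be told apart at this position, even though the entering group has 0 hydrogen-bond acceptors and the leaving group has 2. Compared with 4-methoxyphenyl, the same change gives an 8.4-fold lower number from compound 1 to compound 3 (0.93 log units; beyond the scatter), which shows that a lower number here does not depend on having methoxy groups on the ring, and leaves compound 1 as the one that stands apart. No measurement shown explains why these groups differ as they do.

On these data alone, what happens with an amine or a carboxylic acid on this ring remains open. So does the effect of a longer chain in place of the saturated chain carbon bound to an aromatic nitrogen.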